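Sulfanyl in Place of Chloro on Two Side-Chain Variants

The compounds below may be only part of what the source reports. "The series", "measured", "known", "first", "only" and "open" are said of these compounds alone.

The study measures inhibition in a functional assay on MOLT-4 cells (Homo sapiens) for inhibition; on this read-out higher numbers stand for weaker inhibition and lower numbers for stronger inhibition. Compound 1, `CC(=O)OC(C)n1cnc2c(Cl)nc(N)nc21`, carries a chloro group on its core and reaches only the limit of this assay, giving > 500000 nM, which is a limit and not a number. Compound 2, `CC(=O)OCCOn1cnc2c(Cl)nc(N)nc21`, differs from compound 1 in its side chain; how the two cores differ is not broken down here. In this assay compound 2 likewise returns > 500000 nM, again a limit rather than a number, so that (the limit of > 500000 nM in this assay, at which 2 of the 3 values shown sit).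

Compound 3, `CC(=O)OC(C)n1cnc2c(S)nc(N)nc21`, is compound 1 with sulfanyl in place of chloro on an aromatic carbon. In this assay compound 3 gives 370000 nM, and the step of an at least 1.3-fold lower number from compound 1 to compound 3 (0.13 log units; that floor lies within the scatter) is recorded against a starting point that is itself a limit.

Compound 4, `CC(=O)OCCOn1cnc2c(S)nc(N)nc21`, has not yet been measured in this assay. It is compound 2 with sulfanyl in place of chloro on an aromatic carbon, the same change that leads from compound 1 to compound 3 at the same place on the core. The expectation for compound 4 rests on compound 3 and the step of an at least 1.3-fold lower number from compound 1 to compound 3 (0.13 log units; that floor lies within the scatter), together with the limit that compound 2 shows. The step of an at least 1.2-fold lower number from compound 2 to compound 4 (0.09 log units; that floor lies within the scatter) is therefore expected to be small. Compound 4 is estimated at 400000 nM in this assay, with a range from 150000 nM to 1000000 nM, and it may well again return only a limit.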

Compound 4, half-maximal inhibitory concentration: 8900 nM
Compound 4: middle estimate off by 45-fold (1.65 log units), on the high side; the whole stated range lies above it.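

In this assay the replacement of chloro by sulfanyl on an aromatic carbon, on the side chain of compound 2, gives an at least 56-fold lower number from compound 2 to compound 4 (1.74 log units; beyond the scatter), so the change that did little that could be read on the earlier side chain is here a large one. Set side by side, the two cases of this single change read: the same change on two cores in this assay, an at least 1.3-fold lower number (0.13 log units; that floor lies within the scatter) from compound 1 to compound 3 and an at least 56-fold lower number (1.74 log units; beyond the scatter) from compound 2 to compound 4; the limit leaves it open whether they differ. Within the data shown here, this shows that the change can carry over to a second core of this series with a large drop in the number, but it does not show that the size of the step carries over, and two pairs whose starting points are both limits and not numbers give no measure of either step's true size: the limit of > 500000 nM in this assay, at which 2 of the 4 values shown sit.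

The compounds shown leave open whether an amine or a hydroxyl group on the same aromatic carbon would act as sulfanyl does, and whether a methylsulfanyl group, which keeps the sulfur but not its hydrogen, would stay close to compound 4. They also leave open how compound 4 would respond if its side chain were replaced by a longer chain or ended in a carboxylic acid.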